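The source may hold more compounds than are shown below. What is called first, only, known or untested is meant among the compounds shown, and "the series" means these compounds.

Two compounds of the series have numbers in a functional assay on A549 cells (Homo sapiens) for inhibition, read by MTT assay, with a stated time of 72 h; on this read-out lower numbers stand for stronger inhibition and higher numbers for weaker inhibition. Compound 1 `CN(C(=O)NC(=O)c1ccc(Cl)cc1Cl)c1nc(C(F)(F)F)c(C(=O)N/N=C/c2ccc(C(F)(F)F)cc2)s1` gives 9.4 ug/mL, and compound 2 `CN(C(=O)NC(=O)c1ccc(Cl)cc1Cl)c1nc(C(F)(F)F)c(C(=O)N/N=C/c2ccccc2C(F)(F)F)s1` gives 15.3 ug/mL. Among the measured compounds shown here, the single step between them, a 1.6-fold higher number from compound 1 to compound 2 (0.21 log units; within the scatter), moves the trifluoromethyl on the aryl ring attached to the carbon with a double bond to nitrogen and stays within the scatter. Compound 2 therefore holds the higher of the two numbers, but its gap to compound 1 is within the scatter, so no order between the two is claimed.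

Compound 3 `CN(C(=O)NC(=O)c1cccc([N+](=O)[O-])c1)c1nc(C(F)(F)F)c(C(=O)N/N=C/c2ccccc2C(F)(F)F)s1` differs from compound 2 at a different place: 3-nitrophenyl in place of 2,4-dichlorophenyl on a carbonyl carbon. For the measured compounds named here, no measured step touches the group on the carbonyl carbon, so the one measured step does not bear on this change, and the data give no direction for it. Compound 3 is therefore expected close to compound 2 in this assay, with a step of a 1.0-fold lower number from compound 2 to compound 3 (0.01 log units; within the scatter) expected and a wide range. Compound 3 is estimated at 15 ug/mL, between 6 ug/mL and 40 ug/mL.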

Compound 3, half-maximal inhibitory concentration: 5.45 ug/mL
Estimate against measurement, compound 3: 2.8-fold (0.44 log units) above; the measured number lies below the stated range.
By their numbers in this assay, from the lowest: compounds 3, 1 and 2 (each within the scatter of the next, the first and the last beyond it).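

The group on the carbonyl carbon responds in this assay: with 3-nitrophenyl in place of 2,4-dichlorophenyl, the series shows a 2.8-fold lower number from compound 2 to compound 3 (0.45 log units; beyond the scatter), a modest step and the only one shown that lies beyond the scatter. Among the compounds shown here, the earlier step moved the trifluoromethyl on the other aryl ring and stayed within the scatter, so this carbonyl substituent is the one place so far where a single change separates two compounds. This holds only with 2-(trifluoromethyl)phenyl on the carbon with a double bond to nitrogen, and no measurement shown explains the step.

Going by these compounds, it remains open whether the same change carries over to the 4-(trifluoromethyl)phenyl of compound 1. On these data alone, it is also open whether the step follows the loss of the two chlorines or the entry of the nitro group, which a plain phenyl, a nitrile or an amine on that ring could help separate.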